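The compounds below may be only part of what the source reports. "The series", "measured", "known", "first", "only" and "open" are said of these compounds alone.

In a functional assay on PANC-1 cells (Homo sapiens) for inhibition, read by sulforhodamine B assay, with a stated time of 48 h (a higher number here means a weaker inhibitor of growth, a lower number a stronger inhibitor of growth), compound 1 `Cc1ccn2c(CN3CCCC3)c(-c3ccc(O)cc3)nc2n1` gives 7280 nM and compound 2 `CC(C)(C)c1nc2ncccn2c1CN1CCCCC1` gives 4510 nM, two values within the scatter of each other. Compound 3 `Cc1ccn2c(CN3CCCCC3)c(C(C)(C)C)nc2n1` gives 960 nM, which lies beyond the scatter from both. Compound 1 therefore stands at the high end of these numbers, the end of weaker growth inhibition, level with compound 2.

Compound 4 `Cc1ccn2c(CN3CCCC3)c(-c3ccccc3)nc2n1` departs from compound 1 by a single change (hydrogen in place of hydroxy on an aromatic carbon), with hydrogen in place of hydroxy on an aromatic carbon, so that 4-hydroxyphenyl becomes phenyl. Within the data shown here, no measured pair tests this change. Among the measured compounds shown here, the only measured step, a 4.7-fold lower number from compound 2 to compound 3 (0.67 log units; beyond the scatter), is a different change, methyl in place of hydrogen on an aromatic carbon, and it bears only loosely: it shows that one small edit can move this assay modestly, but it gives no direction here. The expected outcome is therefore no shift beyond the scatter, with an estimated step of a 1.2-fold lower number from compound 1 to compound 4 (0.08 log units; within the scatter) as the working figure. Compound 4 is estimated at 6000 nM, with an expected range of 2200 nM to 16000 nM as its bounds.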

Compound 4, concentration for 50% growth inhibition: 150 nM
Estimate against measurement, compound 4: 40-fold (1.60 log units) above, outside the stated range (below it).
By their numbers in this assay, from the lowest: compound 4; then compound 3; then compounds 2 and 1 (each within the scatter of the next).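

In this assay, among these compounds, hydrogen in place of hydroxy on the aromatic carbon para to a large group gives a 49-fold lower number from compound 1 to compound 4 (1.69 log units; beyond the scatter), a large step, whereas the only earlier step, a 4.7-fold lower number from compound 2 to compound 3 (0.67 log units; beyond the scatter), was modest. This shows that the 4-hydroxyphenyl to phenyl change, which removes only one heavy atom, matters greatly at this position, and that here the number falls when the hydroxy group leaves. No measurement offered here accounts for the size of this step.

The compounds shown leave open whether only the hydroxy group raises the number at this position, or whether a methoxy group, a fluorine atom or an amine there would do the same. They also leave open whether the same change gives a step of similar size on a compound that differs elsewhere.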